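Aryl Group Swap on the Shared Core: Compound 4

A few compounds are considered here, and "the series" means these few. Any claim that something is new, unique, unknown or untested is made for them only; others in the source may bear on it.

Measured in a functional assay on Caco-2 cells (Homo sapiens) for cytotoxicity, with a stated time of 48 h; on this read-out higher numbers stand for weaker inhibition and lower numbers for stronger inhibition:
- compound 1 `O=[N+]([O-])c1ccc(CN2CCC(n3cc(CC(OCc4cc(-c5ccccc5)no4)c4ccc(Br)cc4)nn3)CC2)cc1`: 7000 nM
- compound 2 `O=[N+]([O-])c1ccc(CN2CCC(n3cc(CC(OCc4cc(-c5cccc(F)c5)no4)c4ccc(Br)cc4)nn3)CC2)cc1`: 5000 nM
- compound 3 `COc1cccc(-c2cc(COC(Cc3cn(C4CCN(Cc5ccc([N+](=O)[O-])cc5)CC4)nn3)c3ccc(Br)cc3)on2)c1`: 5000 nM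

Compound 3 sits level with compound 2, the two together giving the lowest numbers of the three; compound 1 is higher by a 1.4-fold lower number from compound 1 to compound 3 (0.15 log units; within the scatter), within the scatter. Compound 4 `O=[N+]([O-])c1ccc(CN2CCC(n3cc(CC(OCc4cc(-c5ccccc5Br)no4)c4ccc(Br)cc4)nn3)CC2)cc1` carries the change (2-bromophenyl in place of 3-methoxyphenyl on an aromatic carbon). The steps that touch the same aromatic carbon, a 1.4-fold lower number from compound 1 to compound 3 (0.15 log units; within the scatter) and no change at the digits printed from compound 2 to compound 3 (within the scatter), both stayed within the scatter, as did a 1.4-fold lower number from compound 1 to compound 2 (0.15 log units; within the scatter). Nothing measured here separates one aryl group from another beyond the scatter, so no step beyond it is expected in this assay for compound 4. The expected step of a 1.1-fold higher number from compound 3 to compound 4 (0.04 log units; within the scatter) is estimated as none beyond the scatter. Compound 4 is expected to give 5500 nM, with a range from 2500 nM to 12000 nM.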

Compound 4, half-maximal inhibitory concentration: 3000 nM
Beside the measured number, compound 4's estimate is 1.8-fold (0.26 log units) above it; the range from low to high includes it.
By their numbers in this assay, from the lowest: compounds 4, 2, 3 and 1 (each within the scatter of the next, the first and the last beyond it).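

In this assay the aryl group on the aromatic carbon next to the ring nitrogen gives its first step beyond the scatter, a modest one, with bromo in place of hydrogen: a 2.3-fold lower number from compound 1 to compound 4 (0.37 log units; beyond the scatter). Against the other substituted aryl groups, 2-bromophenyl stays within the scatter, at a 1.7-fold lower number from compound 3 to compound 4 (0.22 log units; within the scatter) and a 1.7-fold lower number from compound 2 to compound 4 (0.22 log units; within the scatter), so only the comparison with the unsubstituted phenyl separates. Nothing available explains this step.

Open, from the compounds shown here alone, is whether the step depends on bromo itself or on its place on the phenyl ring. Also open, going by these compounds, is how an amine or a carboxylic acid on that ring would read here.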